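This account rests on a few compounds, and the source may have more. Where it says the series, first, only, none or still open, it means among the compounds named here.

The compounds described here share one core and differ only in a single group on one aromatic ring. Compound 1 `COC(=O)N[C@H](C(=O)NN(CCC[C@@](O)(Cc1ccccc1)C(=O)N[C@H]1c2ccccc2C[C@H]1O)Cc1ccc(Br)cc1)C(C)(C)C` carries a bromo group at that position. In an ADME assay on MT4 cells (Homo sapiens) for cytotoxicity (on this read-out higher numbers stand for lower toxicity in this test and lower numbers for higher toxicity in this test), compound 1 gives > 10000 nM, which is a limit of the test and not a number. Compound 2 `COC(=O)N[C@H](C(=O)NN(CCC[C@@](O)(Cc1ccccc1)C(=O)N[C@H]1c2ccccc2C[C@H]1O)Cc1ccc(-n2ccnc2)cc1)C(C)(C)C` gives > 10000 nM in this assay, again a limit. Compound 3 `COC(=O)N[C@H](C(=O)NN(CCC[C@@](O)(Cc1ccccc1)C(=O)N[C@H]1c2ccccc2C[C@H]1O)Cc1ccc(-c2noc(C)n2)cc1)C(C)(C)C` likewise gives > 10000 nM, also a limit. Because all three values sit at the limit of > 10000 nM in this assay, at which 3 of the 3 values shown sit, the steps a step that the two limits leave unreadable from compound 1 to compound 2, a step that the two limits leave unreadable from compound 1 to compound 3 and a step that the two limits leave unreadable from compound 2 to compound 3 cannot be read in size or direction. Compound 4 `COC(=O)N[C@H](C(=O)NN(CCC[C@@](O)(Cc1ccccc1)C(=O)N[C@H]1c2ccccc2C[C@H]1O)Cc1ccc(-c2csc(C)n2)cc1)C(C)(C)C` has not yet been measured and differs from compound 1 by 2-methyl-1,3-thiazol-4-yl in place of bromo on an aromatic carbon. The two measured replacements of bromo bear on this change, but their steps were unreadable, so no step beyond the scatter can be expected in either direction, and another limit is the most likely outcome. Compound 4 is therefore expected to give 20000 nM in this assay, between 10000 nM and 60000 nM, meaning an expected step that the limit leaves unreadable from compound 1 to compound 4.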

Compound 4, half-maximal cytotoxic concentration: > 10000 nM
Compound 4 gave a limit, no number (the forecaster's own chance of this, stated with the estimate: 85%); the middle value is on the limit's open side.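

In this assay compound 4 gives > 10000 nM, a limit and not a number, so its steps from compound 1, compound 2 and compound 3 cannot be read in size or direction: the limit of > 10000 nM in this assay, at which 4 of the 4 values shown sit. The compounds shown leave open whether these four groups differ at all in cytotoxicity, and at what concentration any of the four compounds would harm these cells.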